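A few compounds are considered here, and "the series" means these few. Any claim that something is new, unique, unknown or untested is made for them only; others in the source may bear on it.

Of the compounds shown here, three built on one shared core have so far been tested in an assay on CHO cells for displacement of a labelled ligand from prostaglandin D2 receptor 2 (Homo sapiens), read by scintillation counting; a lower number here means a stronger inhibitor, a higher number a weaker inhibitor. Compound 1 `CN(C)C(=O)c1cccc(C#Cc2cc(Cl)ccc2OCC(=O)O)c1` gives 52 nM in this assay, the second highest of the three numbers. Compound 2 `CCCS(=O)(=O)c1cccc(C#Cc2cc(C#N)ccc2OCC(=O)O)c1` gives 21 nM, a lower number than compound 1 by a margin beyond the usual scatter. Compound 3 `Cc1ccc(S(=O)(=O)N(C)CCCN(C)C)cc1C#Cc1cc(Cl)ccc1OCC(=O)O` gives 287 nM, the highest of the three and well above compound 1.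

Compound 4 `CN(c1cccc(C#Cc2cc(Cl)ccc2OCC(=O)O)c1)S(C)(=O)=O` has not yet been measured. It differs from compound 1 in a single place: methyl(methylsulfonyl)amino in place of dimethylcarbamoyl on an aromatic carbon. Among the compounds with values here, no measured pair shows exactly this change, so the size of the step can only be expected, not read off. Compound 2 also carries a sulfonyl group and gives the lowest number of the set, while compound 3, which carries a sulfonyl-bearing group with a long amine chain, gives the highest; these pull in opposite directions, so only a small step is expected, likely none beyond the scatter. Compound 4 is therefore expected to give 40 nM, within 15 nM to 110 nM. This estimate means an expected step of a 1.3-fold lower number from compound 1 to compound 4 (0.11 log units; within the scatter).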

Compound 4, inhibition constant: 122 nM
Beside the measured number, compound 4's estimate is 3.1-fold (0.48 log units) below it, and the stated range ends below it.
By their numbers in this assay, from the lowest: compound 2; then compound 1; then compound 4; then compound 3.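

In this assay, the change at this aromatic carbon is not neutral: placing methyl(methylsulfonyl)amino where dimethylcarbamoyl stood gives a 2.3-fold higher number from compound 1 to compound 4 (0.37 log units; beyond the scatter), a modest step, but one beyond the usual scatter. Within the data shown here, this is the first comparison in the set with only one place changed, so the shift can be tied to this swap rather than to several differences at once, and compound 1 is the stronger inhibitor of the pair. No available measurement bears on why the number rises.

On these data alone, what a plain amine or a carboxylic acid on this same aromatic carbon would give remains open. Also open, as far as these compounds go, is whether this swap would produce a step of similar size on a version of the shared core carrying a nitrile instead of chlorine.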